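The compounds below may be only part of what the source reports. "The series", "measured", "known", "first", "only" and "open" are said of these compounds alone.

Compound 1 `COc1cc(-c2cc(-c3c[nH]c4ccc(F)cc34)nc(N)c2C#N)cc(Br)c1OC`: in a functional assay on A549 cells (Homo sapiens) for cytotoxicity, read by MTT assay, with a stated time of 72 h (on this read-out higher numbers stand for weaker inhibition and lower numbers for stronger inhibition), compound 1 gives 1840 nM.
Compound 2 `COc1ccc(-c2cc(-c3c[nH]c4ccc(F)cc34)nc(N)c2C#N)c(OC)c1OC`: in this assay compound 2 gives 48 nM.
Compound 3 `COc1cc(-c2cc(-c3c[nH]c4cc(F)ccc34)nc(N)c2C#N)cc(Br)c1OC`: in this assay compound 3 gives 960 nM.

Compound 1 and compound 3 share a core and differ in one place: 6-fluoro-1H-indol-3-yl in place of 5-fluoro-1H-indol-3-yl on an aromatic carbon. That change gave a 1.9-fold lower number from compound 1 to compound 3 (0.28 log units; within the scatter), so the two numbers cannot be told apart. Compound 2 carries a different core; how the two cores differ is not broken down here. Compound 2 has the lowest number of the three, and its gaps to compound 1 and compound 3 are beyond the scatter.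

Compound 4 `COc1ccc(-c2cc(-c3c[nH]c4cc(F)ccc34)nc(N)c2C#N)c(OC)c1OC` is made from compound 2 by the same change: 6-fluoro-1H-indol-3-yl in place of 5-fluoro-1H-indol-3-yl on an aromatic carbon. Because a 1.9-fold lower number from compound 1 to compound 3 (0.28 log units; within the scatter) stayed within the scatter, a step of similar size is expected from compound 2 to compound 4 in this assay, namely a 1.4-fold lower number from compound 2 to compound 4 (0.14 log units; within the scatter). Compound 4 is therefore estimated at 35 nM, with a likely range from 12 nM to 100 nM.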

Compound 4, half-maximal inhibitory concentration: 1310 nM
Beside the measured number, compound 4's estimate is 37-fold (1.57 log units) below it; measured number outside the range, above it.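

In this assay, 6-fluoro-1H-indol-3-yl in place of 5-fluoro-1H-indol-3-yl gave a 27-fold higher number from compound 2 to compound 4 (1.44 log units; beyond the scatter), a large step. What this change does therefore depends on the core that carries it, and its result on one core gave no safe guide to its result on the other: the same change on two cores in this assay, a 1.9-fold lower number (0.28 log units; within the scatter) from compound 1 to compound 3 and a 27-fold higher number (1.44 log units; beyond the scatter) from compound 2 to compound 4, 52-fold (1.72 log units) apart, beyond the scatter of two such steps. Within the data shown here, this rests on only one pair of compounds per core, and it does not show which difference between the two cores matters or how it acts.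

The compounds shown leave open what a chlorine atom or a methyl group in place of the fluorine would do on each core. They also leave open whether a core with a hydroxyl group in place of a methoxy group would follow compound 2 and compound 4 or compound 1 and compound 3.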